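A Single Measured Value and a Methylsulfonyl Replacement

This account rests on a few compounds, and the source may have more. Where it says the series, first, only, none or still open, it means among the compounds named here.

Results so far in a functional assay on ID8 cells (Mus musculus) for antiproliferative activity; a lower number here means a stronger inhibitor, a higher number a weaker inhibitor:
Compound 1 `O=C(Nc1ccc(O)c2c(=O)cc(-c3ccccc3Cl)oc12)c1ccc(Cl)cc1` gives 5500 nM
Compound 2 `O=C(Nc1c(O)cc(O)c2c(=O)cc(-c3ccccc3Cl)oc12)c1ccc(Cl)cc1` is recorded as "not determined" (no result reported)
Compound 3 `COc1ccc(C(=O)Nc2c(O)cc(O)c3c(=O)cc(-c4ccccc4Cl)oc23)cc1` is recorded as "not determined" (no result reported)

Going by the values given here, compound 1 therefore holds the only number. Among the compounds with values here, with no result for compound 2 or compound 3, it cannot be ranked against anything, and the series offers no measured step to serve as a guide.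

Compound 4 `CS(=O)(=O)Nc1ccc(O)c2c(=O)cc(-c3ccccc3Cl)oc12` has not yet been tested. It keeps the core of compound 1 but carries methylsulfonyl in place of (4-chlorophenyl)carbonyl on a nitrogen on an aromatic ring. The one six-membered aromatic ring of carbon only leaves with the outgoing group, and no ring enters.

Within the data shown here, since no measured pair shows what such a change does, the expectation rests on the structural change and on compound 1 at 5500 nM alone. In this assay a modest weakening is expected, though a result within the usual scatter remains quite possible. The estimated shift is (a 1.5-fold higher number from compound 1 to compound 4 (0.16 log units; within the scatter)). For compound 4 the expected half-maximal inhibitory concentration is 8000 nM with an estimated range from 2500 nM to 30000 nM around it.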

Compound 4, half-maximal inhibitory concentration: 16000 nM
Compound 4: middle estimate off by 2.0-fold (0.30 log units), on the low side, within the range that was stated.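

In this assay, the series now has its first readable step: methylsulfonyl in place of (4-chlorophenyl)carbonyl on a nitrogen on an aromatic ring gives a 2.9-fold higher number from compound 1 to compound 4 (0.46 log units; beyond the scatter). The one six-membered aromatic ring of carbon only and the chlorine of the outgoing group are therefore not needed for a measurable antiproliferative value on the shared core, although the number does rise. The swap changes the ring and the linking carbonyl together, so the step cannot show which part accounts for the difference, and no measurement shown here offers an explanation.

The compounds shown leave open whether an acetyl group or a benzenesulfonyl group on the same nitrogen would separate the contribution of the ring from that of the link to the nitrogen. From the compounds shown here alone, it is also open whether a longer chain such as propyl in place of the methyl on the sulfonyl, or a 4-chlorophenyl group there, would bring the number back toward that of compound 1 at 5500 nM.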